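Swapping Nitrooxy for Trifluoromethyl in a Cytotoxicity Series

The source may hold more compounds than are shown below. What is called first, only, known or untested is meant among the compounds shown, and "the series" means these compounds.

Compound 1 `O=C1/C(=C/c2ccccc2F)CN(S(=O)(=O)c2ccc(O[N+](=O)[O-])cc2)C/C1=C\c1ccccc1F` and compound 2 `O=C1/C(=C/c2ccccc2F)CN(S(=O)(=O)c2ccc(C(F)(F)F)cc2)C/C1=C\c1ccccc1F` share one core, while compound 3 `O=C1/C(=C/c2ccc(F)cc2)CN(S(=O)(=O)c2ccc(O[N+](=O)[O-])cc2)C/C1=C\c1ccc(F)cc1` and compound 4 `O=C1/C(=C/c2ccc(F)cc2)CN(S(=O)(=O)c2ccc(C(F)(F)F)cc2)C/C1=C\c1ccc(F)cc1` share another; the difference between the two cores is not broken down here. In a functional assay on HepG2 cells (Homo sapiens) for cytotoxicity, read by MTT assay, with a stated time of 24 h (on this read-out lower numbers stand for stronger inhibition and higher numbers for weaker inhibition), compound 1 gives 16500 nM and compound 2 gives 4900 nM. The change trifluoromethyl in place of nitrooxy on an aromatic carbon produced a 3.4-fold lower number from compound 1 to compound 2 (0.53 log units; beyond the scatter). In this assay compound 3 gives 5400 nM. Compound 4 carries the same kind of change, (trifluoromethyl in place of nitrooxy on an aromatic carbon), and the two place descriptions read alike word for word. Going by the values given here, with only one measured step of this change, the transfer to the core of compound 3 is untested, so a somewhat smaller and less certain step is assumed. Resting on a 3.4-fold lower number from compound 1 to compound 2 (0.53 log units; beyond the scatter), the step expected for compound 4 is a 2.7-fold lower number from compound 3 to compound 4 (0.43 log units; beyond the scatter). Compound 4 is therefore estimated at 2000 nM, between 800 nM and 5000 nM.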

Compound 4, half-maximal inhibitory concentration: 3200 nM
Estimate against measurement, compound 4: 1.6-fold (0.20 log units) below; low and high end bracket the measured number.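

In this assay, trifluoromethyl in place of nitrooxy gives a 1.7-fold lower number from compound 3 to compound 4 (0.23 log units; within the scatter), so on this core the step stays inside the usual scatter, whereas on the core of compound 1 it lies beyond it. Set side by side, the two steps cannot be told apart: the same change on two cores in this assay, a 3.4-fold lower number (0.53 log units; beyond the scatter) from compound 1 to compound 2 and a 1.7-fold lower number (0.23 log units; within the scatter) from compound 3 to compound 4, 2.0-fold (0.30 log units) apart, within the scatter of two such steps. The change can thus be carried between these two cores without a detectable difference in step, but two pairs do not show that the step is truly the same size on both, and they say nothing about any other core.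

The compounds shown leave open how an amine, a carboxylic acid or a nitrile would read at this place on the aromatic ring. As far as these compounds go, whether the step would hold on a third core also remains open.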